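A few compounds are considered here, and "the series" means these few. Any claim that something is new, unique, unknown or untested is made for them only; others in the source may bear on it.

Measured so far:
compound 1, `CCCn1nc(-c2cccnc2)c2ccccc2c1=O`: 86%
compound 2, `CCn1nc(-n2cncn2)c2ccccc2c1=O`: 0%

In an assay on isolated protein (Oryctolagus cuniculus) with Thromboxane-A synthase (Homo sapiens) as the target, tested at 1 uM (a higher number here means more inhibition at the concentration tested (going by the name of the read-out), a lower number less inhibition), compound 1 gives 86% and compound 2 gives 0%. Compound 2 therefore stands at the bottom of the two numbers, and its gap to compound 1 lies beyond the scatter. The two compounds differ in more than one place, so the gap cannot be assigned to a single change.

Compound 3, `CCn1nc(-c2cnccn2)c2ccccc2c1=O`, is not yet measured in this assay. It differs from compound 2 only in one place: pyrazin-2-yl in place of 1H-1,2,4-triazol-1-yl on an aromatic carbon. Going by the values given here, with no step between measured compounds available, the size of the step in this assay is open; a rise beyond the scatter is expected, given that compound 1 carries a six-membered ring with ring nitrogen and gives 86%, while compound 2 gives 0%.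

Compound 3 is expected to give 40%, in the range 5% to 80%, the expected step being a number 40 percentage points higher from compound 2 to compound 3 (beyond the scatter).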

Compound 3, a percentage reported as inhibition, at one concentration (the size of the read-out at that concentration, not a potency): 37%
Estimate against measurement, compound 3: 3 percentage points above, within the range that was stated.
By their numbers in this assay, from the lowest: compound 2; then compound 3; then compound 1.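

In this assay, the aromatic carbon next to the ring nitrogen now has a step of its own: pyrazin-2-yl in place of 1H-1,2,4-triazol-1-yl reads as a number 37 percentage points higher from compound 2 to compound 3 (beyond the scatter). With the ethyl group and the shared core held constant, the read-out responds to the ring at this position alone, which the earlier pair, differing in more than one place, could not show. Nothing available explains what in this change produces the step.

The change alters ring size and the count of ring hetero atoms together, so the two cannot be separated here. From the compounds shown here alone, compound 1 differs from compound 3 in more than one place, and it remains open how a phenyl ring or an amine at this position, or a propyl chain alone in place of the ethyl group, would read.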